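Swapping phenyl for furan-3-yl in a growth inhibitor

This account rests on a few compounds, and the source may have more. Where it says the series, first, only, none or still open, it means among the compounds named here.

In a functional assay on SK-OV-3 cells (Homo sapiens) for antiproliferative activity (a lower number here means a stronger inhibitor of growth, a higher number a weaker inhibitor of growth), the values stand as follows:
Compound 1 `c1ccc(-c2cc(-c3cccnc3)nc(-c3ccccn3)c2)cc1` at 49.6 ug/mL
Compound 2 `c1ccc(-c2cc(-c3ccccn3)nc(-c3ccccn3)c2)cc1` at 0.12 ug/mL

Among the compounds with values here, compound 2 holds the lowest number so far. Within the data shown here, the one measured step is a 410-fold lower number from compound 1 to compound 2 (2.62 log units; beyond the scatter) and puts pyridin-2-yl in place of pyridin-3-yl, so it bears only indirectly on the next change. Compound 3 `c1ccc(-c2cc(-c3ccoc3)cc(-c3ccccn3)n2)nc1` differs from compound 2 by furan-3-yl in place of phenyl on an aromatic carbon and keeps both pyridin-2-yl groups. Among the measured compounds shown here, no measured step covers furan-3-yl in place of phenyl. In this assay a large step is therefore not expected, and a 2.5-fold higher number from compound 2 to compound 3 (0.40 log units; beyond the scatter) is the estimated small move toward a higher number. Compound 3 is estimated at 0.3 ug/mL with 0.04 ug/mL to 2 ug/mL as its expected range.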

Compound 3, concentration for 50% growth inhibition: 0.6 ug/mL
Compound 3: the middle estimate sits 2.0-fold (0.30 log units) below what was measured; low and high end bracket the measured number.
By their numbers in this assay, from the lowest: compound 2; then compound 3; then compound 1.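

In this assay, the position opposite the ring nitrogen accepts a five-membered aromatic ring with an oxygen in place of the six-membered carbon ring, at a modest cost: a 5.0-fold higher number from compound 2 to compound 3 (0.70 log units; beyond the scatter). Phenyl and furan-3-yl are thus not equivalent here, yet compound 3 still gives 0.6 ug/mL. Nothing at hand accounts for this rise.

Open, from the compounds shown here alone, is how thiophen-3-yl or furan-2-yl would fare at this position. Also open, going by these compounds, is whether an amine or a carboxylic acid carried on the phenyl ring would be accepted there.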